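The source may hold more compounds than are shown below. What is called first, only, known or untested is meant among the compounds shown, and "the series" means these compounds.

Compound 1 `Fc1ccc2c(c1CNc1ncc(Oc3ccccc3)c3nncn13)CCO2`: 3.5
Compound 2 `Cc1nc(CN(C)C)ccc1-c1cnc(NCc2c(F)ccc3c2CCO3)c2cn[nH]c(=O)c12`: 2

In a physicochemical assay for lipophilicity, using the shake flask method, in phosphate buffer, measured as octanol-water partition, with a stated time of 30 min, at pH 7.4 (on this read-out lower numbers stand for lower lipophilicity and higher numbers for higher lipophilicity), compound 1 gives 3.5, the higher of the two numbers, and compound 2 gives 2, a gap that lies beyond the scatter. Compound 3 `O=C1CC2(CC2)CN1c1cnc(NCc2c(F)ccc3c2CCO3)n2cnnc12` is not yet measured. It differs from compound 1 as follows: a group of 8 heavy atoms (6 carbon, 1 nitrogen, 1 oxygen; one three-membered non-aromatic ring of carbon only, one five-membered non-aromatic ring with 1 hetero atom) in place of a group of 7 heavy atoms (6 carbon, 1 oxygen; one six-membered aromatic ring of carbon only), on an aromatic carbon. Because compound 1 stands at 3.5, the step from compound 1 to compound 3 is expected to be downward and clearly beyond the scatter, about a number 1.50 log units lower from compound 1 to compound 3 (beyond the scatter). For compound 3 the estimate in this assay is 2, expected to fall between 1.4 and 2.6.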

Compound 3, distribution coefficient: 1.9
Estimate against measurement, compound 3: 0.10 log units above; the range from low to high includes it.
By their numbers in this assay, from the lowest: compounds 3 and 2 (each within the scatter of the next); then compound 1.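

In this assay, putting the group with a three-membered carbon ring and a five-membered non-aromatic ring in place of phenoxy on this aromatic carbon gives a number 1.60 log units lower from compound 1 to compound 3 (beyond the scatter), so the read-out responds strongly to a change at this one position. The step occurs although both groups carry no net charge and have equal counts of hydrogen-bond donors and acceptors. Nothing available gives a cause for this step. The compounds shown leave open how a cyclohexyloxy group or a simple amine would read at this carbon. They also leave open whether the step follows the departure of the aromatic ring or the arrival of the carbonyl-bearing ring.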